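This account rests on a few compounds, and the source may have more. Where it says the series, first, only, none or still open, it means among the compounds named here.

Measured in an ADME assay on K562 cells (Homo sapiens) for cytotoxicity, with a stated time of 72 h (on this read-out higher numbers stand for weaker inhibition and lower numbers for stronger inhibition), each entry being a limit:
Compound 1 `COc1cc(CNc2ncnc3c2ncn3C2CCCCO2)cc(OC)c1`: > 100000 nM
Compound 2 `Oc1cccc(CNc2ncnc3c2ncn3C2CCCO2)c1`: > 100000 nM
Compound 3 `COc1cccc(CNc2ncnc3c2ncn3C2CCCO2)c1`: > 100000 nM

Compound 3 has only a limit, > 100000 nM, and the two other values are limits as well. Compound 4 `COc1cc(CNc2ncnc3c2ncn3C2CCCO2)cc(OC)c1` differs from it by one change, methoxy in place of hydrogen on an aromatic carbon. For the measured compounds named here, the one measured step, a step that the two limits leave unreadable from compound 2 to compound 3, puts methyl in place of hydrogen on an oxygen on an aromatic ring and gives no size to carry over. What remains is the limit of > 100000 nM in this assay, at which 3 of the 3 values shown sit. On that basis, no step beyond the scatter is expected in this assay, and a further limit is likely. The expected step is a number no higher from compound 3 to compound 4 (the limit leaves the size open). For compound 4 the estimate is 100000 nM, with an expected range of 40000 nM to 200000 nM.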

Compound 4, half-maximal inhibitory concentration: > 100000 nM
Compound 4: a limit, no number; the forecaster's own chance of this, stated with the estimate: 85%; the middle value sits exactly at the limit.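

No step can be read from compound 3 to compound 4 or from compound 1 to compound 4, as both pairs give only limits: the limit of > 100000 nM in this assay, at which 4 of the 4 values shown sit. The compounds shown leave open what size, if any, these changes have in this assay.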